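The source may report more compounds than this note shows. Statements on the series, on what has been measured and on what is new or still open speak of the compounds shown alone.

In a functional assay on MKN-45 cells (Homo sapiens) for cytotoxicity, read by MTT assay, with a stated time of 72 h (on this read-out lower numbers stand for stronger inhibition and higher numbers for weaker inhibition), compound 2, `COc1cc2c(Oc3ccc(NC(=O)c4nnn(-c5ccccc5)c4C)cc3F)ccnc2cc1OCCCN1CCCCC1`, gives 80 nM. Among the two compounds for which numbers are in hand this is the higher one, but its nearest neighbour, compound 1 with the structure `COc1cc2c(Oc3ccc(NC(=O)c4nnn(-c5ccccc5C(F)(F)F)c4C)cc3F)ccnc2cc1OCCCN1CCCC1`, gives in this assay 70 nM, and the two numbers lie within the scatter of each other, so no order between compound 1 and compound 2 can be read from them. Compound 1 already carries a trifluoromethyl group on its phenyl ring, and its number shows that such a group is compatible with potency of this order.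

Compound 3, `COc1cc2c(Oc3ccc(NC(=O)c4nnn(-c5ccccc5C(F)(F)F)c4C)cc3F)ccnc2cc1OCCCN1CCCCC1`, has not yet been measured. It arises from compound 2 by a single change: trifluoromethyl in place of hydrogen on an aromatic carbon, which is trifluoromethyl in place of hydrogen on an aromatic carbon. Among the measured compounds shown here, nothing in the numbers so far points to a step beyond the scatter in either direction for this change, since compound 1 with its trifluoromethyl group gives 70 nM in this assay and compound 2 without one gives 80 nM. The step of a 1.1-fold lower number from compound 2 to compound 3 (0.03 log units; within the scatter) is therefore expected to be small. For compound 3 a value of 75 nM is estimated, in the range from 35 nM to 160 nM.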

Compound 3, half-maximal inhibitory concentration: 90 nM
Beside the measured number, compound 3's estimate is 1.2-fold (0.08 log units) below it, and the stated range covers the measured number.
By their numbers in this assay, from the lowest: compounds 1, 2 and 3 (each within the scatter of the next).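

Among the compounds shown here, with the piperidin-1-yl chain held fixed, this assay gives a 1.1-fold higher number from compound 2 to compound 3 (0.05 log units; within the scatter) for trifluoromethyl in place of hydrogen on an aromatic carbon, ortho to a large group; this is the first direct reading of that change, as compounds 1 and 2 differ in more than one place. For the compounds shown here, with trifluoromethyl held fixed, piperidin-1-yl in place of pyrrolidin-1-yl gives a 1.3-fold higher number from compound 1 to compound 3 (0.11 log units; within the scatter) in this assay and so provides the first direct reading at the end of the chain, where neither step shows a difference that can be separated from the scatter. The data offer no measured basis for explaining why either step is this size.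

These two pairs leave open whether a fluorine atom, a methoxy group or a nitrile on the same aromatic carbon would also stay within the scatter of compound 2. They also leave open how this assay would respond if a morpholin-4-yl group, a dimethylamino group or a carboxylic acid took the place of the ring amine, or if the chain carrying it were longer.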